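Swapping the ester-bearing arm for an oxazole ether

The source may hold more compounds than are shown below. What is called first, only, known or untested is meant among the compounds shown, and "the series" means these compounds.

Measured so far:
compound 1, `C[C@@H]1CC[C@H]2C(=O)[C@H]3O[C@]3(C)CC[C@@H]3O[C@@]3(C)CC[C@]1(C)[C@H]2CO`: 30000 nM
compound 2, `C/C1=C\CC[C@@]2(C)O[C@@H]2C(=O)[C@@H]2CC[C@@H](C)[C@](C)(CC1)[C@H]2COC(=O)Oc1ccccc1`: 550 nM

Both compounds were tested in an assay (Oryctolagus cuniculus) for inhibition of platelet-activating factor receptor (Cavia porcellus); a lower number here means a stronger inhibitor, a higher number a weaker inhibitor. Compound 1 gives 30000 nM in this assay. Compound 2 gives 550 nM in this assay, the lower of the two numbers, and its gap to compound 1 lies well beyond the scatter.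

Compound 3, `C/C1=C\CC[C@@]2(C)O[C@@H]2C(=O)[C@@H]2CC[C@@H](C)[C@](C)(CC1)[C@H]2COc1ccon1`, has not yet been measured. It differs from compound 2 in one place: 1,2-oxazol-3-yl in place of phenoxycarbonyl on an oxygen on a saturated carbon. For the measured compounds named here, no pair of measured compounds differs only in this place, so there is no measured step to lean on. The expectation is a small step, most likely toward a higher number but possibly none beyond the scatter. Compound 3 is expected to give about 1000 nM in this assay, within a range from 200 nM to 5000 nM. This expected change amounts to a 1.8-fold higher number from compound 2 to compound 3 (0.26 log units; within the scatter).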

Compound 3, half-maximal inhibitory concentration: 50 nM
Compound 3: middle estimate off by 20-fold (1.30 log units), on the high side, and the stated range ends above it.
By their numbers in this assay, from the lowest: compound 3; then compound 2; then compound 1.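

In this assay, exchanging phenoxycarbonyl for 1,2-oxazol-3-yl on this oxygen gives an 11-fold lower number from compound 2 to compound 3 (1.04 log units; beyond the scatter), a large step beyond the scatter. The position therefore responds strongly to the group it carries, and the phenoxycarbonyl is not needed for a low number here: a group of 5 heavy atoms, with a five-membered aromatic ring and no carbonyl outside it, does better than one of 9 heavy atoms. Nothing available explains why the number falls.

Going by these compounds, this single swap changes the ring, its size and the carbonyl all at once, so their separate contributions remain unknown. A phenyl ether, a pyridine ring or a plain methyl on the same oxygen would help tell whether the 1,2-oxazol-3-yl ring itself matters or whether losing the phenoxycarbonyl is enough.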